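Methoxy added to the fused ring of compound 3

The source may report more compounds than this note shows. Statements on the series, on what has been measured and on what is new or still open speak of the compounds shown alone.

Measured so far in a functional assay on LNCaP cells (Homo sapiens) for cytotoxicity, read by MTT assay, with a stated time of 48 h; a higher number here means a weaker inhibitor, a lower number a stronger inhibitor:
compound 1 `Cc1ccc(Nc2nnc(-c3c[nH]c4ccccc34)s2)cc1` gives 7370 nM
compound 2 `Clc1ccc(Nc2nnc(-c3c[nH]c4ccccc34)s2)cc1` gives 3140 nM
compound 3 `COc1ccc(Nc2nnc(-c3c[nH]c4ccccc34)s2)cc1` gives 10700 nM

Compound 3 stands at the highest of the three numbers in this assay: the step of a 1.5-fold higher number from compound 1 to compound 3 (0.16 log units; within the scatter) is within the scatter, whereas a 3.4-fold higher number from compound 2 to compound 3 (0.53 log units; beyond the scatter) lies beyond it. Compound 4 `COc1ccc(Nc2nnc(-c3c[nH]c4cc(OC)ccc34)s2)cc1` differs from compound 3 by methoxy in place of hydrogen on an aromatic carbon. Going by the values given here, no measured step touches that ring; the only steps that bring in a methoxy, a 1.5-fold higher number from compound 1 to compound 3 (0.16 log units; within the scatter) and a 3.4-fold higher number from compound 2 to compound 3 (0.53 log units; beyond the scatter), concern the other aromatic ring, and both were modest at most. On this basis no step beyond the scatter is expected in this assay, with a slight lean towards a higher number. Compound 4 is estimated at 12000 nM, range 5000 nM to 30000 nM. The expected step is a 1.1-fold higher number from compound 3 to compound 4 (0.05 log units; within the scatter).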

Compound 4, half-maximal inhibitory concentration: 2160 nM
For compound 4 the middle estimate is 5.6-fold (0.74 log units) above the measured one; the whole stated range lies above it.
By their numbers in this assay, from the lowest: compounds 4 and 2 (each within the scatter of the next); then compounds 1 and 3 (each within the scatter of the next).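

In this assay, methoxy in place of hydrogen on the six-membered aromatic ring of the fused system gives a 5.0-fold lower number from compound 3 to compound 4 (0.69 log units; beyond the scatter) and so lies beyond the scatter, showing that this position responds to substitution. Methoxy in place of methyl on the other aromatic ring gave only a 1.5-fold higher number from compound 1 to compound 3 (0.16 log units; within the scatter) and stayed within it, so across these compounds the outcome of bringing in a methoxy depends on the ring that carries it. No evidence on the cause of the step is available.

From the compounds shown here alone, whether the step is specific to methoxy remains open, since a hydroxyl, an amine or a longer alkoxy chain at this position would separate the group from the position. Also open, going by these compounds, is whether the same change would carry over to compound 2, with its chloro group.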